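This account rests on a few compounds, and the source may have more. Where it says the series, first, only, none or still open, it means among the compounds named here.

Measured in a functional assay on MDA-MB-231 cells (Homo sapiens) for cytotoxicity, read by MTT assay, with a stated time of 72 h; on this read-out higher numbers stand for weaker inhibition and lower numbers for stronger inhibition:
compound 1 `O=C1c2c[n+]([O-])c3ccccc3c2C(=O)c2c1c1ccccc1n2CCCCn1ccnc1`: 210 nM
compound 2 `O=C1c2c[n+]([O-])c3ccccc3c2C(=O)c2c1c1ccccc1n2Cc1cn(C[C@H](O)CO)nn1`: 1310 nM
compound 3 `O=C1c2c[n+]([O-])c3ccccc3c2C(=O)c2c1c1ccccc1n2CCCCN1CCCCC1`: 610 nM

Compound 3, at 610 nM, holds the second highest of the three numbers in this assay, with compound 1 lower and compound 2 higher.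

The next compound is compound 4 `O=C1c2c[n+]([O-])c3ccccc3c2C(=O)c2c1c1ccccc1n2CCN1CCCCC1`. The change is piperidin-1-yl in place of 2-(piperidin-1-yl)ethyl on a saturated chain carbon, two bonds along the chain from an aromatic nitrogen. Read further out, 4-(piperidin-1-yl)butyl becomes 2-(piperidin-1-yl)ethyl.

Among the compounds with values here, no measured step alters this chain alone while keeping piperidin-1-yl, so the evidence is indirect. The closest step is a 2.9-fold higher number from compound 1 to compound 3 (0.46 log units; beyond the scatter), an exchange of the end group on the same chain. Wider exchanges of the whole side chain give a 2.1-fold lower number from compound 2 to compound 3 (0.33 log units; beyond the scatter) and a 6.2-fold higher number from compound 1 to compound 2 (0.80 log units; beyond the scatter). All three are modest, and none indicates a direction for the change at hand. No step beyond the scatter is therefore expected in this assay, though the range stays wide. The expected step is a 1.2-fold lower number from compound 3 to compound 4 (0.09 log units; within the scatter). For compound 4 the estimated value is 500 nM, with an expected range from 170 nM to 1500 nM.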

Compound 4, half-maximal inhibitory concentration: 1050 nM
For compound 4 the middle estimate is 2.1-fold (0.32 log units) below the measured one; the range from low to high includes it.
By their numbers in this assay, from the lowest: compound 1; then compounds 3, 4 and 2 (each within the scatter of the next, the first and the last beyond it).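

Notes on the side chain at this position, in this assay: with piperidin-1-yl kept as the end group, 2-(piperidin-1-yl)ethyl in place of 4-(piperidin-1-yl)butyl gives a 1.7-fold higher number from compound 3 to compound 4 (0.24 log units; within the scatter), so this first direct read of chain length finds no difference that the assay can separate. The 2-(piperidin-1-yl)ethyl side chain is likewise not separated from the 1-(2,3-dihydroxypropyl)-1H-1,2,3-triazol-4-yl side chain, at a 1.2-fold lower number from compound 2 to compound 4 (0.10 log units; within the scatter), although the two side chains differ in both end group and linker. The side chain of compound 1 remains apart from this one, at a 5.0-fold higher number from compound 1 to compound 4 (0.70 log units; beyond the scatter), a step that combines a different chain with a different end group and so does not assign the gap to either.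

No measurement is available that bears on the origin of these numbers. Open, going by these compounds, are whether 2-(1H-imidazol-1-yl)ethyl would stay with compound 1 or fall with compound 4, and how a chain longer than 4-(piperidin-1-yl)butyl or a morpholine or dimethylamine end group would read in this assay.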